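Aryl imine series: nitro in place of methoxy

This account rests on a few compounds, and the source may have more. Where it says the series, first, only, none or still open, it means among the compounds named here.

Measured so far in a functional assay on P388 cells (Mus musculus) for cytotoxicity, read by MTT assay, with a stated time of 72 h; a higher number here means a weaker inhibitor, a lower number a stronger inhibitor:
Compound 1 `CCOc1cccc(/C=N/c2c(C)n(C)n(-c3ccccc3)c2=O)c1`: 295000000 nM
Compound 2 `COc1cccc(/C=N/c2c(C)n(C)n(-c3ccccc3)c2=O)c1`: 105000000 nM

Within the data shown here, compound 2 holds the lowest of the two numbers in this assay; the sole measured step is a 2.8-fold lower number from compound 1 to compound 2 (0.45 log units; beyond the scatter), a change confined to the alkoxy chain. Compound 3 `Cc1c(/N=C/c2cccc([N+](=O)[O-])c2)c(=O)n(-c2ccccc2)n1C` differs from compound 2 by nitro in place of methoxy on an aromatic carbon, meta to a large group. Among the measured compounds shown here, no measured step covers a change of this kind, so the expectation rests only on the modest size of that one step. The estimated step is a 1.1-fold lower number from compound 2 to compound 3 (0.02 log units; within the scatter), not beyond the scatter. Compound 3 is expected at 100000000 nM, within 30000000 nM to 330000000 nM.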

Compound 3, half-maximal inhibitory concentration: 490000000 nM
Beside the measured number, compound 3's estimate is 4.9-fold (0.69 log units) below it; the whole stated range lies below it.
By their numbers in this assay, from the lowest: compound 2; then compounds 1 and 3 (each within the scatter of the next).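

In this assay, among these compounds, this aromatic carbon, meta to a large group, tolerates a change of group less well than the one earlier step suggested: nitro in place of methoxy gives a 4.7-fold higher number from compound 2 to compound 3 (0.67 log units; beyond the scatter). Nitro in place of ethoxy gives a 1.7-fold higher number from compound 1 to compound 3 (0.22 log units; within the scatter), so these two groups cannot be told apart here, and compound 2 keeps the lowest number of the three. No evidence on the cause of these differences is available.

Open, going by these compounds, is whether an amine, a chlorine or a longer alkoxy chain here would give a number lower than that of compound 2. Also open, on these data alone, is whether the same order holds at other carbons of this ring.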